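This account rests on a few compounds, and the source may have more. Where it says the series, first, only, none or still open, it means among the compounds named here.

Measured in a physicochemical assay for solubility, measured as kinetic solubility (a higher number here means a more soluble compound, a lower number a less soluble compound), so far:
- Compound 1 `O=C(Nc1cc(Oc2cccnc2)cc([N+](=O)[O-])c1)c1ccc(F)cc1` gives < 1 ug/mL
- Compound 2 `O=C(Nc1cccc(Oc2cccnc2)c1)c1ccc(F)cc1` gives 17 ug/mL
- Compound 3 `O=C(Nc1ccc(F)cc1)Nc1cc(F)cc(Oc2cccnc2)c1` gives 1.1 ug/mL

The entry for compound 1 is a limit of the assay and not a number. That leaves two true numbers. Compound 3 is the lower of them (1.1 ug/mL), and compound 2 stands higher (17 ug/mL), with a gap beyond the scatter.

Compound 4 `O=C(Nc1cccnc1)Nc1cc(F)cc(Oc2cccnc2)c1` has not yet been measured. It keeps the rest of compound 3 but carries pyridin-3-yl in place of 4-fluorophenyl on an amide-type nitrogen.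

Among the measured compounds shown here, only one measured step is available: an at least 17-fold higher number from compound 1 to compound 2 (1.23 log units; beyond the scatter). That step is hydrogen in place of nitro on an aromatic carbon, so it is a different change in a different place. For the measured compounds named here, it shows only that a single change can move a number far in this assay and does not set the size here. Going by the values given here, no measured pair swaps these two groups, so the expectation is a cautious one: a higher number, probably beyond the scatter, but smaller than that large step.

The step expected is a 4.5-fold higher number from compound 3 to compound 4 (0.66 log units; beyond the scatter).

For compound 4 the estimate is 5 ug/mL, with an expected range from 1.5 ug/mL to 20 ug/mL.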

Compound 4, solubility: 46 ug/mL
Estimate against measurement, compound 4: 9.2-fold (0.96 log units) below; measured number outside the range, above it.
By their numbers in this assay, from the lowest: compound 3; then compound 2; then compound 4. At a limit, below all of these: compound 1.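

In this assay, replacing 4-fluorophenyl with pyridin-3-yl on an amide-type nitrogen gives a 42-fold higher number from compound 3 to compound 4 (1.62 log units; beyond the scatter), so a single swap at this position, which the earlier step did not touch, can move the number a long way. Among the compounds shown here, compound 1 holds a limit of the assay and not a number, so the one earlier step, made at another place on the core, gave only a bound: the limit of < 1 ug/mL in this assay, at which 1 of the 4 values shown sits. Compound 3 and compound 4 both carry true numbers, so the new step has a full size, though this one pair cannot tell whether the loss of the fluorine or the arrival of the ring nitrogen accounts for it.

Plain phenyl at this position would help separate those two parts of the swap, while pyridin-4-yl would show whether the place of the ring nitrogen matters. A saturated amine or a carboxylic acid on the same ring lies outside the compounds shown as well, so it remains open how far the gain extends beyond this one pair.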